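The source may report more compounds than this note shows. Statements on the series, on what has been measured and on what is new or still open speak of the compounds shown alone.

Measured so far in an ADME assay on HepG2 cells (Homo sapiens) for inhibition, with a stated time of 48 h; a higher number here means that more compound is needed for the effect, a lower number that less compound is needed (all three compounds):

- compound 1 `CNc1nc(Nc2ccc(OC)cc2)nc2ccccc12` gives 26100 nM 
- compound 2 `Fc1cccc(Nc2nc(NCC3CCCO3)c3ccccc3n2)c1` gives 8600 nM 
- compound 3 `Fc1ccccc1Nc1nc(NCC2CCCO2)c2ccccc2n1` gives 21300 nM 

Compound 3 lies within the scatter of compound 1 and clearly apart from compound 2. Compound 4 `NC(=O)c1ccc(Nc2nc(NCC3CCCO3)c3ccccc3n2)cc1` has not yet been measured. It carries 4-carbamoylphenyl in place of 2-fluorophenyl on a nitrogen on an aromatic ring. For the measured compounds named here, one measured step bears on this place: a 2.5-fold higher number from compound 2 to compound 3 (0.39 log units; beyond the scatter) (modest), where 2-fluorophenyl replaces 3-fluorophenyl. Going by the values given here, that step shows the number can move when this group changes, but no measured compound carries a carbamoyl group, so the direction stays open. Taking compound 2 at 8600 nM and compound 3 at 21300 nM as the only span seen at this place, a step of no more than modest size is expected, and most likely none beyond the scatter. The expected step is a 1.2-fold lower number from compound 3 to compound 4 (0.07 log units; within the scatter) (an estimate). For compound 4 the estimated value is 18000 nM (expected range 6000 nM to 50000 nM).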

Compound 4, half-maximal effective concentration: 34600 nM
Estimate against measurement, compound 4: 1.9-fold (0.28 log units) below, within the range that was stated.
By their numbers in this assay, from the lowest: compound 2; then compounds 3, 1 and 4 (each within the scatter of the next).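

In this assay, replacing the 2-fluorophenyl group with 4-carbamoylphenyl gives a 1.6-fold higher number from compound 3 to compound 4 (0.21 log units; within the scatter), so this change at the nitrogen on an aromatic ring, which brings more heavy atoms, a hydrogen-bond donor and a hydrogen-bond acceptor, leaves the two compounds indistinguishable. Replacing 3-fluorophenyl with the same group gives a 4.0-fold higher number from compound 2 to compound 4 (0.60 log units; beyond the scatter), which shows that among the three groups compared at this place, only 3-fluorophenyl stands apart from the other two. No supporting evidence is available to explain these results.

The compounds shown leave open whether the separation of compound 2 belongs to the fluorine at that ring position or to the 3-substituted phenyl pattern in general. They also leave open how a 3-carbamoylphenyl group, or a carboxylic acid or an amine in place of the carbamoyl group, would behave at this place.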